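Phenyl in place of propyl on an amide-type nitrogen

A few compounds are considered here, and "the series" means these few. Any claim that something is new, unique, unknown or untested is made for them only; others in the source may bear on it.

Of the compounds shown here, three sharing one core have been measured in a functional assay on MDA-MB-436 cells (Homo sapiens) for antiproliferative activity, read by MTT assay, with a stated time of 48 h; a lower number here means a stronger inhibitor, a higher number a weaker inhibitor. Compound 1 `C=CS(=O)(=O)N1CCN(c2ncnc3sc(-c4ccc(N5CCN(C)CC5)cc4)cc23)CC1` gives 8760 nM, compound 2 `CCS(=O)(=O)N1CCN(c2ncnc3sc(-c4ccc(N5CCN(C)CC5)cc4)cc23)CC1` gives 10600 nM, and compound 3 `CCCNC(=O)N1CCN(c2ncnc3sc(-c4ccc(N5CCN(C)CC5)cc4)cc23)CC1` gives 12400 nM. Compound 3 lies within the scatter of both others, so the three sit at one level and cannot be ranked.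

Compound 4 `CN1CCN(c2ccc(-c3cc4c(N5CCN(C(=O)Nc6ccccc6)CC5)ncnc4s3)cc2)CC1` differs from compound 3 in one group: phenyl in place of propyl on an amide-type nitrogen.

Among the compounds with values here, no measured step tests this exchange directly. The closest evidence comes from changes on the amine nitrogen in a ring, which give a 1.4-fold higher number from compound 1 to compound 3 (0.15 log units; within the scatter) and a 1.2-fold higher number from compound 2 to compound 3 (0.07 log units; within the scatter), and from the change on the sulfonyl sulfur, which gives a 1.2-fold higher number from compound 1 to compound 2 (0.08 log units; within the scatter). All three steps lie within the scatter, but none brings in a ring, so the range is kept wide. On the evidence of a 1.2-fold higher number from compound 2 to compound 3 (0.07 log units; within the scatter), no step beyond the scatter is expected in this assay, and no direction is favoured.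

The expected change is a 1.2-fold lower number from compound 3 to compound 4 (0.09 log units; within the scatter), which is estimated to stay within the scatter. Compound 4 is estimated at 10000 nM, with an expected range of 4500 nM to 22000 nM.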

Compound 4, half-maximal inhibitory concentration: 7090 nM
Estimate against measurement, compound 4: 1.4-fold (0.15 log units) above; low and high end bracket the measured number.
By their numbers in this assay, from the lowest: compounds 4, 1, 2 and 3 (each within the scatter of the next).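

Phenyl in place of propyl is the first exchange in the series to put a six-membered aromatic ring of carbon only on the amide-type nitrogen, and in this assay it gives a 1.7-fold lower number from compound 3 to compound 4 (0.24 log units; within the scatter) and so stays within the scatter. Set against the sulfonyl compounds, phenylcarbamoyl on the amine nitrogen in a ring gives a 1.5-fold lower number from compound 2 to compound 4 (0.17 log units; within the scatter) and a 1.2-fold lower number from compound 1 to compound 4 (0.09 log units; within the scatter) and also stays within the scatter, so compound 4 joins the other three at one level, and at this position neither the ring nor the propyl chain separates from the ethylsulfonyl or vinylsulfonyl groups. No measurement on these compounds offers an explanation of this flat result.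

Still open, as far as these compounds go, is whether the same level holds with a substituted ring, such as a phenyl carrying a methoxy group or a carboxylic acid, or with a benzyl group or a longer chain on the same nitrogen. Also open is whether any group at this position can shift the number beyond the scatter, as every step among these four compounds lies within it.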